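The compounds below may be only part of what the source reports. "The series", "measured", "known", "first", "only" and "open" are said of these compounds alone.

Notes on the series. In an assay on isolated protein for inhibition of serine protease 1 (Homo sapiens) (on this read-out higher numbers stand for weaker inhibition and lower numbers for stronger inhibition), compound 1 `CC1(C)C2CC1[C@]1(C)OB([C@H](CCCN=C(N)N)NC(=O)c3ccc(-c4ccccc4)cc3)O[C@@H]1C2` gives 33 nM. For the measured compounds named here, compound 2 `Cc1cc(-c2ccccc2)ccc1C(=O)N[C@@H](CCCN=C(N)N)B1O[C@@H]2CC3CC(C3(C)C)[C@]2(C)O1` gives 4.2 nM in this assay, the lower of the two numbers so far; the only measured step, a 7.9-fold lower number from compound 1 to compound 2 (0.90 log units; beyond the scatter), separates it from compound 1. Compound 3 `Cc1cc(-c2ccccc2C(F)(F)F)ccc1C(=O)N[C@@H](CCCN=C(N)N)B1O[C@@H]2CC3CC(C3(C)C)[C@]2(C)O1` has not yet been measured. The change from compound 2 to compound 3 is trifluoromethyl in place of hydrogen on an aromatic carbon, on an aromatic carbon of a six-membered aromatic ring of carbon only, ortho to a large group; read one bond further out it is phenyl to 2-(trifluoromethyl)phenyl. Going by the values given here, no measured step bears on this change directly: the single known step concerns methyl in place of hydrogen on an aromatic carbon, and nothing in the data shows how a trifluoromethyl acts. The expectation for this assay is therefore a step of a 1.2-fold higher number from compound 2 to compound 3 (0.08 log units; within the scatter), within the scatter and in no fixed direction. Compound 3 is estimated at 5 nM, with a range of 1.5 nM to 16 nM.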

Compound 3, inhibition constant: 3.1 nM
The estimate for compound 3 lay 1.6-fold (0.21 log units) above the measured number; the measured number falls inside the stated range.
By their numbers in this assay, from the lowest: compounds 3 and 2 (each within the scatter of the next); then compound 1.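

In this assay, trifluoromethyl in place of hydrogen on an aromatic carbon ortho to a large group gives a 1.4-fold lower number from compound 2 to compound 3 (0.13 log units; within the scatter), so compound 3 and compound 2 stand level. For the compounds shown here, compounds 1 and 2 both carry hydrogen here, so this is the first reading of any other group at this position, and a group of 4 heavy atoms leaves the number within the scatter. Nothing available explains this tolerance.

As far as these compounds go, whether an amine, a carboxylic acid, a methyl or a single fluorine at this position would also leave the number in place remains open. So does whether trifluoromethyl would be tolerated on another carbon of the same ring, and a single substituent at one position supports no trend across groups.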